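From pyrimidin-2-yl to 1,3-thiazol-2-yl on a sulfonamide nitrogen

The source may hold more compounds than are shown below. What is called first, only, known or untested is meant among the compounds shown, and "the series" means these compounds.

compound 1 `C=C1CC[C@@H]2[C@](C)(COC(C)=O)[C@H](OC(C)=O)CC[C@@]2(C)[C@H]1CC(Nc1ccc(S(=O)(=O)Nc2ccc(Cl)nn2)cc1)C1=CCOC1=O`: "not determined" (no result reported)
compound 2 `C=C1CC[C@@H]2[C@](C)(COC(C)=O)[C@H](OC(C)=O)CC[C@@]2(C)[C@H]1CC(Nc1ccc(S(=O)(=O)Nc2nccc(C)n2)cc1)C1=CCOC1=O`: > 100000 nM
compound 3 `C=C1CC[C@@H]2[C@](C)(COC(C)=O)[C@H](OC(C)=O)CC[C@@]2(C)[C@H]1CC(Nc1ccc(S(=O)(=O)Nc2ncccn2)cc1)C1=CCOC1=O`: > 100000 nM

All three measured compounds share the core shown with compound 1 and differ only in the group on the sulfonamide nitrogen. In a functional assay on MCF7 cells (Homo sapiens) for inhibition, read by sulforhodamine B assay, with a stated time of 48 h (on this read-out lower numbers stand for higher toxicity in this test and higher numbers for lower toxicity in this test), compound 1 gives "not determined" (no result reported), so no number is available for it. Compound 2 reaches only the limit of this assay, > 100000 nM. Compound 3 likewise stands at the limit, > 100000 nM. Two of the three entries thus sit at the limit of > 100000 nM in this assay, at which 2 of the 3 values shown sit. For the measured compounds named here, the only step between measured compounds, a step that the two limits leave unreadable from compound 2 to compound 3, has a limit at both ends and cannot be read. Compound 3 therefore stands at a limit, with one further limit and one entry without a number beside it.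

Compound 4 `C=C1CC[C@@H]2[C@](C)(COC(C)=O)[C@H](OC(C)=O)CC[C@@]2(C)[C@H]1CC(Nc1ccc(S(=O)(=O)Nc2nccs2)cc1)C1=CCOC1=O` has not yet been measured. It differs from compound 3 by 1,3-thiazol-2-yl in place of pyrimidin-2-yl on a sulfonamide nitrogen. Going by the values given here, no measured step bears directly on this change: the one step available, a step that the two limits leave unreadable from compound 2 to compound 3, concerns a different part of the group and is itself unreadable. With both measured neighbours at the limit, compound 4 is expected to give in this assay a value again at or near the limit, estimated at 100000 nM within 30000 nM to 300000 nM. The step of a number no higher from compound 3 to compound 4 (the limit leaves the size open) is accordingly expected to stay within the scatter.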

Compound 4, concentration lethal to 50% of the cells: > 100000 nM
Compound 4: no number, only a limit; the forecaster's own chance of this, stated with the estimate: 70%; the middle value lies on the limit itself.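

In this assay compound 4 gives > 100000 nM, which is a limit and not a number. The steps to compound 4 from compound 2 and from compound 3 cannot be read, since both ends of each are limits: the limit of > 100000 nM in this assay, at which 3 of the 4 values shown sit. The compounds shown leave open whether any group on the sulfonamide nitrogen gives a measurable value in this assay.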